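The source may hold more compounds than are shown below. What is called first, only, known or untested is meant among the compounds shown, and "the series" means these compounds.

Working notes on the series.

Compound 1 `COc1ccc(C2=C(c3cc(OC)c(OC)c(OC)c3)C(=O)C(O)C2)cc1` carries a free hydroxyl on a saturated ring carbon. In an ADME assay on MIA PaCa-2 cells (Homo sapiens) for cytotoxicity, read by MTT assay, with a stated time of 72 h (on this read-out higher numbers stand for weaker inhibition and lower numbers for stronger inhibition), compound 1 gives < 1 ug/mL, which is a limit of the assay and not a number. Compound 3 `COc1ccc(C2=C(c3cc(OC)c(OC)c(OC)c3)C(=O)C(O[SiH2]C(C)(C)C)C2)cc1` differs from compound 1 by a group of 5 heavy atoms (4 carbon, 1 silicon; no ring) in place of a hydrogen atom, on an oxygen on a saturated carbon. In this assay compound 3 gives < 1 ug/mL, again a limit rather than a number. The step that the two limits leave unreadable from compound 1 to compound 3 therefore has no readable size, because both of its ends sit at the limit of < 1 ug/mL in this assay, at which 2 of the 3 values shown sit.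

Compound 2 `COc1ccc(C2=C(c3cc(OC)c(OC)c(OC)c3)CC(O)C2=O)cc1[N+](=O)[O-]` has a different core; how the core of compound 2 differs from the core of compound 1 is not broken down here. In this assay, for the measured compounds named here, compound 2 gives > 100 ug/mL, a limit of the assay and not a number, and it is the single value sitting at the limit of > 100 ug/mL in this assay, at which 1 of the 3 values shown sits.

Compound 4 `COc1ccc(C2=C(c3cc(OC)c(OC)c(OC)c3)CC(O[SiH2]C(C)(C)C)C2=O)cc1[N+](=O)[O-]` has not yet been measured in this assay. It differs from compound 2 by a group of 5 heavy atoms (4 carbon, 1 silicon; no ring) in place of a hydrogen atom, on an oxygen on a saturated carbon, the same change that leads from compound 1 to compound 3, at the same place.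

Going by the values given here, the one precedent for this change gives no readable size, since compound 1 and compound 3 both sit at a limit, so nothing measured here points to a large move in either direction. Compound 2 itself starts at a limit, and the step from compound 2 to compound 4 is expected to be about a number no higher from compound 2 to compound 4 (the limit leaves the size open). Compound 4 is therefore estimated at 100 ug/mL in this assay, with a range from 30 ug/mL to 300 ug/mL, and a considerable chance that the assay again returns only a limit.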

Compound 4, half-maximal inhibitory concentration: > 100 ug/mL
Compound 4: a limit, no number; the forecaster's own chance of this, stated with the estimate: 65%; the middle value lies on the limit itself.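

The step between compound 2 and compound 4 cannot be read, as both compounds stand at a limit in this assay and not at a number: the limit of > 100 ug/mL in this assay, at which 2 of the 4 values shown sit.

The compounds shown leave open whether a group of 5 heavy atoms (4 carbon, 1 silicon; no ring) in place of the hydrogen atom moves the value at all, on the core of compound 1 or on the core of compound 2.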